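The source may hold more compounds than are shown below. What is called first, only, known or untested is meant among the compounds shown, and "the series" means these compounds.

Measured in a functional assay on a cell-free system (plasma, Homo sapiens), with a stated time of 3 min; a lower number here means a stronger inhibitor, a higher number a weaker inhibitor:
- Compound 1 `Cc1cccc([C@@H](O)C(=O)N2N=CC[C@H]2C(=O)NCc2cc(Cl)ccc2-n2cnnn2)c1`: 830 nM
- Compound 2 `O=C(NCc1cc(Cl)ccc1-n1cnnn1)[C@@H]1[C@@H]2C[C@@H]2CN1C(=O)[C@H](O)Cc1ccccn1`: 1700 nM
- Compound 3 `CC(C)CC[C@@H](O)C(=O)N1N=CC[C@H]1C(=O)NCc1cc(Cl)ccc1-n1cnnn1`: 630 nM

Compound 2 has the highest number of the three and is the weakest inhibitor here, with compound 1 and compound 3 both lower by more than the scatter. Compound 4 `O=C(NCc1cc(Cl)ccc1-n1cnnn1)[C@@H]1[C@@H]2C[C@@H]2CN1C(=O)[C@H](O)c1ccccc1F` differs from compound 2 at one place: 2-fluorophenyl in place of (pyridin-2-yl)methyl on a saturated chain carbon bound to a carbonyl carbon and an oxygen on a saturated carbon. For the measured compounds named here, only one measured step touches that place, with isopentyl in place of 3-methylphenyl: a 1.3-fold lower number from compound 1 to compound 3 (0.12 log units; within the scatter). That step stays within the scatter, but it was measured on the core of compound 1, not on the core of compound 2, so it is only a loose guide. Going by the values given here, no measured compound carries 2-fluorophenyl. On this evidence, no change beyond the scatter is expected in this assay. The estimated step is a 1.4-fold lower number from compound 2 to compound 4 (0.15 log units; within the scatter), which would stay within the scatter. Compound 4 is expected at 1200 nM, with an estimated range of 400 nM to 3500 nM.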

Compound 4, half-maximal inhibitory concentration: 580 nM
Compound 4: middle estimate off by 2.1-fold (0.32 log units), on the high side, and the stated range covers the measured number.
By their numbers in this assay, from the lowest: compounds 4, 3 and 1 (each within the scatter of the next); then compound 2.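

In this assay the change to 2-fluorophenyl gives a 2.9-fold lower number from compound 2 to compound 4 (0.47 log units; beyond the scatter) and so shows that, on the core of compound 2, the group on this saturated chain carbon can move the number beyond the scatter, which the earlier step on the core of compound 1 did not show. The leaving and entering groups have the same count of heavy atoms and each holds one six-membered aromatic ring, so the step arises without any change in either of those counts. No measurement at hand gives a reason for this step. The compounds shown do not separate the entry of the fluorine from the loss of the ring nitrogen or of the methylene link, and a plain phenyl or a benzyl group here would bear on that. On these data alone, whether the step carries over to the core of compound 1 also stays open.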